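Swapping an alkylamino for a methoxyethoxy side chain

This account rests on a few compounds, and the source may have more. Where it says the series, first, only, none or still open, it means among the compounds named here.

Compound 1 `CCCNc1nc(N)nc2c1ncn2/C=C1/CC1(CO)CO` belongs to a small set of purine derivatives that share one core and differ only in the group attached to it. Its tolerance by cells was followed in an ADME assay on MOLT-3 cells (Homo sapiens) for cytotoxicity, with a stated time of 7 days; a lower number here means that less compound is tolerated, a higher number that more compound is tolerated; for compound 1 itself the result is "not determined" (no result reported), so no number places it on the scale. Compound 2 `CC(C)CNc1nc(N)nc2c1ncn2/C=C1/CC1(CO)CO` likewise stands at "not determined" (no result reported) in this assay. Compound 3 `CCCOc1nc(N)nc2c1ncn2/C=C1/CC1(CO)CO` carries a propoxy group on the core, and in this assay compound 3 reaches only > 20000 nM, which is a limit of the assay rather than a number. Going by the values given here, that limit is the sole piece of evidence among the three: the limit of > 20000 nM in this assay, at which 1 of the 3 values shown sits. Among the compounds with values here, with no single number for compound 1 and no step between measured compounds, there is nothing on which a direction could be read.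

Compound 4 `COCCOc1nc(N)nc2c1ncn2/C=C1/CC1(CO)CO` is the next compound to be tested. It differs from compound 1 as follows: 2-methoxyethoxy in place of propylamino on an aromatic carbon. Since the only measured relative, compound 3, sits at the limit, no step beyond the usual scatter is expected in this assay, in either direction. Compound 4 is therefore estimated to give 20000 nM in this assay, with an expected range from 8000 nM to 50000 nM.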

Compound 4, half-maximal cytotoxic concentration: > 20000 nM
Compound 4: a limit, no number; the forecaster's own chance of this, stated with the estimate: 80%; the middle value lies on the limit itself.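

Compound 3 and compound 4 each stand at a limit of this assay, not at a number, so no step between them can be read: the limit of > 20000 nM in this assay, at which 2 of the 4 values shown sit.

The compounds shown leave open where on the scale either compound truly lies, and whether swapping propylamino for 2-methoxyethoxy, the difference between compound 1 and compound 4, changes cell tolerance at all.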